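The source may hold more compounds than are shown below. What is called first, only, known or untested is meant among the compounds shown, and "the series" means these compounds.

Of the compounds shown here, three have so far been measured in an assay on isolated protein for inhibition of protein kinase C zeta type (Homo sapiens), read by mobility shift assay, tested at 30 uM; a higher number here means more inhibition at the concentration tested (going by the name of the read-out), a lower number less inhibition. Compound 1 `COc1ccc(-c2cc3[nH]nc(N)c3c(=O)[nH]2)cc1` gives 7%, compound 2 `Cc1cc2c(c(N)nn2C)c(=O)[nH]1` gives 0%, and compound 3 `Cn1nc(N)c2c(=O)[nH]c(-c3ccccc3)cc21` gives 6%. Compound 3 thus stands second highest of the three numbers, while lying within the scatter of both compound 1 and compound 2. Compound 4 `COc1ccc(-c2cc3c(c(N)nn3C)c(=O)[nH]2)cc1` differs from compound 3 by methoxy in place of hydrogen on an aromatic carbon. Among the measured compounds shown here, no measured step makes this same change; the only step at hand is a number 6 percentage points higher from compound 2 to compound 3 (within the scatter), and compound 1 and compound 3 give numbers within the scatter of each other. Compound 4 is therefore expected to show no change at the digits printed from compound 3 to compound 4 (within the scatter), no shift beyond the scatter. The estimate for compound 4 is 6%, in a range from 0% to 16%.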

Compound 4, a percentage reported as inhibition, at one concentration (the size of the read-out at that concentration, not a potency): -3%
Beside the measured number, compound 4's estimate is 9 percentage points above it; the measured number lies below the stated range.
By their numbers in this assay, from the lowest: compounds 4, 2, 3 and 1 (each within the scatter of the next).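

In this assay, among the compounds shown here, methoxy in place of hydrogen on an aromatic carbon, para to a large group, comes with a number 9 percentage points lower from compound 3 to compound 4 (within the scatter), the only reading of this change at this position. Methyl in place of hydrogen on an aromatic nitrogen, with that methoxy present, comes with a number 10 percentage points lower from compound 1 to compound 4 (within the scatter), so neither change moves the number beyond the scatter. Nothing at hand offers a reason for these numbers. Whether an amine or a carboxylic acid in place of the methoxy would give a number beyond the scatter stays open, since the compounds shown hold only hydrogen and methoxy at this position.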